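A few compounds are considered here, and "the series" means these few. Any claim that something is new, unique, unknown or untested is made for them only; others in the source may bear on it.

Of the compounds shown here, two from this study have been measured. The first, compound 1 with the structure `CC(=O)NCCN(C)c1cccc(OCCCCCCNC(=O)Oc2cccc(-c3ccccc3)c2)c1`, binds the receptor well: in an assay on cells for displacement of a labelled ligand from melatonin receptor type 1B (Homo sapiens), using the Cheng-Prusoff equation, with a stated time of 90 min (a higher number here means a weaker inhibitor, a lower number a stronger inhibitor), compound 1 gives 33.1 nM. The second, compound 2 with the structure `CC(=O)NCCN(C)c1cccc(OCCCCCCOc2cccc(OC(=O)NC3CCCCC3)c2)c1`, is weaker: in this assay compound 2 gives 295 nM. Compound 1 thus has the lowest of the two numbers, and the gap to compound 2, the nearest of them, lies beyond the usual scatter. For the measured compounds named here, the two differ in more than one place, so no single structural step between them can be read off.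

Compound 3, with the structure `CC(=O)NCCN(C)c1cccc(OCCCCCCNC(=O)Oc2cccc(-c3cccc(C(N)=O)c3)c2)c1`, has not yet been measured. It differs from compound 1 in one place only: carbamoyl in place of hydrogen on an aromatic carbon. Going by the values given here, since no measured pair shows the effect of this same change, the expectation rests on the general picture that a small addition of this kind usually moves the number only modestly. In this assay compound 3 is expected to give about 50 nM, with a likely range from 12 nM to 200 nM. The estimated step of a 1.5-fold higher number from compound 1 to compound 3 (0.18 log units; within the scatter) is expected to stay close to the usual scatter, with the measurement to follow.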

Compound 3, inhibition constant: 15.5 nM
The estimate for compound 3 lay 3.2-fold (0.51 log units) above the measured number; measured number inside the range.
By their numbers in this assay, from the lowest: compound 3; then compound 1; then compound 2.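

Replacing phenyl with 3-carbamoylphenyl gives a 2.1-fold lower number from compound 1 to compound 3 (0.33 log units; beyond the scatter) in this assay, so this change on an aromatic carbon, meta to a large group, is not merely tolerated but comes with a modest gain in binding. For the compounds shown here, until now, the only comparison available was between compound 1 and compound 2, which differ in more than one place, so nothing could be said about this position on its own. This single clean step shows that the position can take a group of 3 heavy atoms, with a hydrogen-bond donor and a hydrogen-bond acceptor, without any loss, although nothing available here explains the lower number.

A single step cannot show whether the gain is specific to carbamoyl or would also appear with another group at this position, such as a carboxylic acid, an amine or a methyl ester. The compounds shown also leave open whether carbamoyl would do the same elsewhere on this ring, or whether the same change would give a similar step on the core of compound 2.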